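Removing chloro in a series at the assay limit

The source may report more compounds than this note shows. Statements on the series, on what has been measured and on what is new or still open speak of the compounds shown alone.

Measured in an ADME assay on cells (Homo sapiens) for antiproliferative activity; a higher number here means a weaker inhibitor, a lower number a stronger inhibitor:
compound 1 `COc1ccc(N=C2NC(=O)/C(=C\c3ccc(N(C)C)cc3)S2)cc1`: a limit, > 100000 nM
compound 2 `CN(C)c1ccc(/C=C2/SC(=Nc3ccc(O)cc3)NC2=O)cc1`: a limit, > 100000 nM
compound 3 `CN(C)c1ccc(/C=C2/SC(=Nc3ccccc3Cl)NC2=O)cc1`: a limit, > 100000 nM

Compound 3 gives no number, only the limit > 100000 nM. It has no better-defined neighbour, since the whole series shares one reading: the limit of > 100000 nM in this assay, at which 3 of the 3 values shown sit.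

The next change leads to compound 4 `CN(C)c1ccc(/C=C2/SC(=Nc3ccccc3)NC2=O)cc1`: hydrogen in place of chloro on an aromatic carbon. In words, this is hydrogen in place of chloro on an aromatic carbon, ortho to a large group, or 2-chlorophenyl to phenyl.

The closest measured steps also change the group on the double-bonded nitrogen: a step that the two limits leave unreadable from compound 1 to compound 3 and a step that the two limits leave unreadable from compound 2 to compound 3. A third, a step that the two limits leave unreadable from compound 1 to compound 2, changes a methyl on an oxygen. None of them gives a size, so no size can be carried over to the new step. The expectation therefore rests on compound 3 and a step that the two limits leave unreadable from compound 2 to compound 3 alone, and no step beyond the scatter is expected in this assay, in either direction.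

The estimate is a number no higher from compound 3 to compound 4 (the limit leaves the size open), an expected step that stays small. Compound 4 is expected at 100000 nM, with an estimated range of 40000 nM to 150000 nM. A limit rather than a number is the likely report.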

Compound 4, half-maximal inhibitory concentration: > 100000 nM
Compound 4: no number, only a limit (the forecaster's own chance of this, stated with the estimate: 80%); the middle value sits exactly at the limit.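

Compound 4, like compound 1, compound 2 and compound 3, gives only a limit in this assay, so no step among these compounds can be read: the limit of > 100000 nM in this assay, at which 4 of the 4 values shown sit.

On these data alone, whether phenyl, 2-chlorophenyl, 4-hydroxyphenyl and 4-methoxyphenyl on the double-bonded nitrogen differ at all in antiproliferative activity stays open, as does how far each compound lies from the limit.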